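The compounds below may be only part of what the source reports. "The series", "measured", "known", "first", "only" and "open" are said of these compounds alone.

Compound 1 `CCOC(=O)C(=O)Nc1cccccc1=O` — 91%
Compound 2 `CC(C)(C)OC(=O)C(=O)Nc1cccccc1=O` — 82%
Compound 3 `O=C(O)C(=O)Nc1cccccc1=O` — 62%; 68%; 73% (3 entries)

In a functional assay on the whole organism (strain Sprague-Dawley CD) for inhibition, with Rattus norvegicus as the target, read by paw edema, at a dose of 100 mg/kg by the oral route (on this read-out higher numbers stand for a stronger effect at the one dose given and lower numbers for a weaker effect), compound 1 gives 91% and compound 2 gives 82%; the step of a number 9 percentage points lower from compound 1 to compound 2 (within the scatter) sits within the scatter. Among the single numbers compound 2 stands lowest, with compound 1 nearest. Compound 3 gives 62%; 68%; 73% (3 entries) in this assay, and its repeated entries the several entries of compound 3 in this assay, 62%; 68%; 73% (3 entries) show how far repeats of this kind wander.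

Compound 4 `CCOC(=O)COC(=O)C(=O)Nc1cccccc1=O` has not yet been measured. It differs from compound 2 in one place: (ethoxycarbonyl)methyl in place of tert-butyl on an oxygen next to a carbonyl group. For the measured compounds named here, the only measured step that bears on this change is the one from compound 1 to compound 2, which also swaps one group for another on the oxygen next to the carbonyl and stayed within the scatter. On that basis a step of a number 2 percentage points lower from compound 2 to compound 4 (within the scatter) is expected to stay within the scatter, with no clear direction. Compound 4 is therefore estimated at 80% in this assay, with a range from 65% to 92%.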

Compound 4, a percentage reported as inhibition, in the whole organism at one dose (the size of the read-out at that dose, not a potency): 64%
Compound 4: middle estimate off by 16 percentage points, on the high side; the measured number lies below the stated range.
By their numbers in this assay, from the lowest: compound 4; then compounds 2 and 1 (each within the scatter of the next).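

In this assay the group on an oxygen next to a carbonyl group proves not to be freely exchangeable: the earlier swap of tert-butyl for ethyl stayed within the scatter, whereas (ethoxycarbonyl)methyl in place of tert-butyl gives a number 18 percentage points lower from compound 2 to compound 4 (beyond the scatter). Set against the ethyl group, ethoxycarbonyl in place of methyl on a saturated chain carbon bound to that oxygen gives a number 27 percentage points lower from compound 1 to compound 4 (beyond the scatter), so the drop appears from both measured neighbours and does not rest on one comparison alone. Even so, this single reading has to be weighed against how far repeats wander here: the several entries of compound 3 in this assay, 62%; 68%; 73% (3 entries)

On these data alone, whether the ethoxycarbonyl part itself matters, or whether a plain longer chain such as butyl would read the same, remains open. So does how an amine in place of the ethoxycarbonyl would read.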